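The source may report more compounds than this note shows. Statements on the series, on what has been measured and on what is new or still open speak of the compounds shown alone.

Measured in a functional assay on CHO cells (Homo sapiens) for antiproliferative activity against CHO (Cricetulus griseus), read by sulforhodamine B assay, with a stated time of 48 h; a lower number here means a stronger inhibitor, a higher number a weaker inhibitor:

- compound 1 `Cc1cccc(NS(=O)(=O)c2ccc(N3CCNC3=O)cc2)c1`: 230 nM
- compound 2 `COc1cc(NS(=O)(=O)c2ccc(N3CCNC3=O)cc2)cc(OC)c1OC`: 190 nM
- compound 3 `Cc1cc(C)cc(NS(=O)(=O)c2ccc(N3CCNC3=O)cc2)c1`: 210 nM

Compound 2 stands level with the other two compounds, since all three values lie within the usual scatter of one another. Compound 4 `COc1cc(NS(=O)(=O)c2ccc(N3CCNC3=O)cc2)cc(OC)c1` departs from compound 2 by a single change, (hydrogen in place of methoxy on an aromatic carbon), with hydrogen in place of methoxy on an aromatic carbon, ortho to two methoxy groups and para to a large group.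

Within the data shown here, no measured step covers the loss of a methoxy group directly. The nearest evidence is a 1.1-fold lower number from compound 1 to compound 3 (0.04 log units; within the scatter), which is also a single substitution on an aromatic carbon, methyl in place of hydrogen, and stays within the scatter. Compound 3, which carries no methoxy group, gives 210 nM, and this value sits within the scatter of that of compound 2. No change beyond the scatter is therefore expected in this assay, and no direction can be assigned with confidence.

The expected change is a 1.2-fold higher number from compound 2 to compound 4 (0.08 log units; within the scatter). For compound 4 the estimated value is 230 nM, with an expected range from 110 nM to 500 nM.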

Compound 4, half-maximal inhibitory concentration: 330 nM
Beside the measured number, compound 4's estimate is 1.4-fold (0.16 log units) below it; the range from low to high includes it.
By their numbers in this assay, from the lowest: compounds 2, 3, 1 and 4 (each within the scatter of the next).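

In this assay, hydrogen in place of methoxy on an aromatic carbon, ortho to two methoxy groups and para to a large group, gives a 1.7-fold higher number from compound 2 to compound 4 (0.24 log units; within the scatter). Among these compounds, this is the first direct reading of the methoxy group at this position: the earlier step, a 1.1-fold lower number from compound 1 to compound 3 (0.04 log units; within the scatter), concerned methyl in place of hydrogen on an aromatic carbon, and now a methoxy group can also be exchanged for hydrogen without a step beyond the scatter. No available evidence accounts for the size of this step.

The compounds shown leave open whether an amine, a carboxylic acid or a longer chain on this carbon would give a step beyond the scatter. They also leave open what the two remaining methoxy groups contribute in this assay.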